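A few compounds are considered here, and "the series" means these few. Any claim that something is new, unique, unknown or untested is made for them only; others in the source may bear on it.

Compound 1 `CN(c1ncco1)c1cnc(NCc2c(F)ccc3c2CCO3)n2cnnc12` has the lowest number of the three compounds measured in an ADME assay on microsomes from liver (Homo sapiens) for metabolic stability, read by LC-MS, using NADPH, with stated times of 5 min and 30 min, tested at 1 uM (a lower number here means slower removal, a higher number faster removal of the compound), at 11 mL.min-1.g-1. Compound 2 `Cc1nc(CN(C)C)ccc1-c1cnc(NCc2c(F)ccc3c2CCO3)c2cn[nH]c(=O)c12` gives 13 mL.min-1.g-1, a result that lies within the usual scatter of the result for compound 1. Compound 3 `CN(C)Cc1ccc2c(c1)CN(c1cnc(NCc3c(F)ccc4c3CCO4)c3cn[nH]c(=O)c13)C2=O` gives 32 mL.min-1.g-1, a higher number that lies beyond the scatter. Compound 4 `CN(c1cccnc1)c1cnc(NCc2c(F)ccc3c2CCO3)n2cnnc12` has not yet been measured; it differs from compound 1 in one place: pyridin-3-yl in place of 1,3-oxazol-2-yl on a nitrogen on an aromatic ring. Within the data shown here, no step between the measured compounds matches this change, so the measured data give no direct guide. The expectation is a small rise in this assay, most likely not beyond the scatter. The step from compound 1 to compound 4 is expected to be a 1.5-fold higher number from compound 1 to compound 4 (0.16 log units; within the scatter). For compound 4 the estimated value is 16 mL.min-1.g-1, with a range from 7 mL.min-1.g-1 to 35 mL.min-1.g-1.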

Compound 4, intrinsic clearance in microsomes: 80 mL.min-1.g-1
Compound 4: the middle estimate sits 5.0-fold (0.70 log units) below what was measured; the measured number lies above the stated range.
By their numbers in this assay, from the lowest: compounds 1 and 2 (each within the scatter of the next); then compound 3; then compound 4.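

In this assay the change from 1,3-oxazol-2-yl to pyridin-3-yl on this nitrogen gives a 7.3-fold higher number from compound 1 to compound 4 (0.86 log units; beyond the scatter) and so lies beyond the usual scatter. It is the first step shown in which only one place differs, and it shows that the ring on this nitrogen alone can shift the number substantially. Nothing measured here accounts for the rise.

Still open, from the compounds shown here alone, is how a phenyl or pyrimidin-5-yl ring on this nitrogen would compare. Also open, going by these compounds, is whether a morpholine in place of the ring would keep the number near that of compound 1.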